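The source may hold more compounds than are shown below. What is called first, only, known or untested is meant among the compounds shown, and "the series" means these compounds.

Measured in a physicochemical assay for solubility, using the shake flask method, in simulated intestinal fluid, measured as kinetic solubility, with a stated time of 2 h, at 25 degrees C, at pH 6.5; a lower number here means a less soluble compound, a higher number a more soluble compound:
Compound 1 `Cc1noc(-c2nc(C)c3c(c2N)C(=O)N(Cc2ccccc2)C3=O)n1`: < 5000 nM, a limit.
Compound 2 `Cc1noc(-c2nc(C)c3c(c2N)C(=O)N(Cc2ccc(Oc4ccc(F)cc4)cc2)C3=O)n1`: 23800 nM.
Compound 3 `Cc1noc(-c2nc(C)c3c(c2N)C(=O)N(Cc2ccc(C(F)(F)F)cc2)C3=O)n1`: < 5000 nM, a limit.

Compound 3 has no number, only a limit: the limit of < 5000 nM in this assay, at which 2 of the 3 values shown sit. Compound 4 `Cc1noc(-c2nc(C)c3c(c2N)C(=O)N(Cc2ccc(OC(F)(F)F)cc2)C3=O)n1` carries trifluoromethoxy in place of trifluoromethyl on an aromatic carbon, para to a large group (trifluoromethoxy in place of trifluoromethyl on an aromatic carbon).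

For the measured compounds named here, two steps bear on this change, although neither tests trifluoromethoxy. The first, a step that the two limits leave unreadable from compound 1 to compound 3, introduces trifluoromethyl. The second, an at least 4.7-fold lower number from compound 2 to compound 3 (0.67 log units; beyond the scatter), removes 4-fluorophenoxy, the only group seen to lift a value clear of the limit, as shown by an at least 4.7-fold higher number from compound 1 to compound 2 (0.67 log units; beyond the scatter). No step beyond the scatter is therefore expected in this assay. The expected step is a step that the limit leaves unreadable from compound 3 to compound 4. Compound 4 is estimated at 4000 nM, within an expected range of 1500 nM to 12000 nM.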

Compound 4, solubility: < 5000 nM
Compound 4 ended at the assay's limit (the forecaster's own chance of this, stated with the estimate: 70%); the middle value is on the limit's open side.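

In this assay compound 4 gives only a limit, so its steps from compound 1 and compound 3 cannot be read. Trifluoromethoxy, like trifluoromethyl, leaves the value short of what 4-fluorophenoxy gives, with an at least 4.7-fold lower number from compound 2 to compound 4 (0.67 log units; beyond the scatter). Compound 2 alone now stands clear of the limit at this position: the limit of < 5000 nM in this assay, at which 3 of the 4 values shown sit.

Going by these compounds, how compound 1, compound 3 and compound 4 rank among themselves stays open. So does whether an amine or a carboxylic acid at this position would lift the value clear of the limit, as 4-fluorophenoxy does.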